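Moving the methoxy group on the distal aryl ring

This account rests on a few compounds, and the source may have more. Where it says the series, first, only, none or still open, it means among the compounds named here.

The series shares one core and varies only the terminal aryl ring of the biaryl amide. Compound 1 `COC(=O)C(Cc1cccc(C(=N)N)c1)C(/C=C/c1ccccc1)NC(=O)c1ccc(-c2ccc(C)cc2)cc1` gives 2800 nM in an assay on isolated protein (Oryctolagus cuniculus) for inhibition of Trypsin (Homo sapiens); a higher number here means a weaker inhibitor, a lower number a stronger inhibitor. Compound 2 `CCc1cccc(-c2ccc(C(=O)NC(/C=C/c3ccccc3)C(Cc3cccc(C(=N)N)c3)C(=O)OC)cc2)c1` gives 2600 nM in this assay, and compound 3 `COC(=O)C(Cc1cccc(C(=N)N)c1)C(/C=C/c1ccccc1)NC(=O)c1ccc(-c2ccccc2OC)cc1` gives 1800 nM. Compound 3 has the lowest of the three numbers, but its steps to the other two are small: a 1.6-fold lower number from compound 1 to compound 3 (0.19 log units; within the scatter) and a 1.4-fold lower number from compound 2 to compound 3 (0.16 log units; within the scatter); the step of a 1.1-fold lower number from compound 1 to compound 2 (0.03 log units; within the scatter) is likewise within the scatter, so no order among the three is established.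

Compound 4 `COC(=O)C(Cc1cccc(C(=N)N)c1)C(/C=C/c1ccccc1)NC(=O)c1ccc(-c2cccc(OC)c2)cc1` is not yet measured. It differs from compound 3 in the following way: 3-methoxyphenyl in place of 2-methoxyphenyl on an aromatic carbon. Among the compounds with values here, no measured step swaps one methoxyphenyl for another, so the bearing of the three known steps is indirect: each of them exchanges one substituted phenyl for another at the same aromatic carbon, and each stayed within the scatter. On that basis the change from compound 3 to compound 4 is expected to produce no step beyond the scatter in this assay, with the expected step being a 1.1-fold higher number from compound 3 to compound 4 (0.05 log units; within the scatter). For compound 4 the estimate in this assay is 2000 nM, within a range of 1000 nM to 4200 nM.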

Compound 4, half-maximal inhibitory concentration: 2200 nM
Compound 4: middle estimate off by 1.1-fold (0.04 log units), on the low side; low and high end bracket the measured number.
By their numbers in this assay, from the lowest: compounds 3, 4, 2 and 1 (each within the scatter of the next).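

Swapping one methoxyphenyl directly for another, with 3-methoxyphenyl in place of 2-methoxyphenyl on the aromatic carbon para to a large group, gives a 1.2-fold higher number from compound 3 to compound 4 (0.09 log units; within the scatter) in this assay and so shows that this move of the methoxy group, with the same atoms joined differently, stays within the scatter. The comparison with an ethyl group at the same place on the ring gives a 1.2-fold lower number from compound 2 to compound 4 (0.07 log units; within the scatter) and the exchange of 4-methylphenyl for 3-methoxyphenyl gives a 1.3-fold lower number from compound 1 to compound 4 (0.10 log units; within the scatter), so all four terminal rings now stand within the scatter and compound 4 adds no separation within the series. Nothing available accounts for this flat response.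

As far as these compounds go, only neutral methyl, ethyl and methoxy substituents on the terminal phenyl ring are covered here, so it remains open whether a hydroxy group, an amine, a carboxylic acid or a longer chain at this ring would produce a step beyond the scatter. From the compounds shown here alone, it is also open whether the flat response holds for the other parts of the shared core, which are the same in all four compounds.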